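The compounds below may be only part of what the source reports. "The series", "measured", "known", "first", "only" and "open" are said of these compounds alone.

In a functional assay on HT-29 cells (Homo sapiens) for inhibition, read by MTT assay, with a stated time of 48 h (a lower number here means a stronger inhibitor, a higher number a weaker inhibitor), compound 1 `Cc1ccc(NC(=S)NC(=O)c2ccc(OCc3ccccc3F)cc2)cc1-c1nc2ccccc2[nH]1` gives 1870 nM, the lowest of the two numbers at hand, while compound 2 `Cc1ccc(COc2ccc(C(=O)NC(=S)Nc3ccc(C)c(-c4nc5ccccc5[nH]4)c3)cc2)cc1` gives 14200 nM. Within the data shown here, the one measured step, a 7.6-fold higher number from compound 1 to compound 2 (0.88 log units; beyond the scatter), is the only guide available. Compound 3 `Cc1ccc(NC(=S)NC(=O)c2ccc(OCc3ccc(F)cc3)cc2)cc1-c1nc2ccccc2[nH]1` differs from compound 1 in one place: 4-fluorophenyl in place of 2-fluorophenyl on a saturated chain carbon bound to an oxygen on an aromatic ring. Both changes replace the 2-fluorophenyl, but only the measured one also exchanges fluorine for methyl, so a weaker version of that rise is expected here. Compound 3 is therefore expected to give 4200 nM, within 1500 nM to 12000 nM, an expected step of a 2.2-fold higher number from compound 1 to compound 3 (0.35 log units; beyond the scatter).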

Compound 3, half-maximal inhibitory concentration: 1910 nM
Compound 3: the middle estimate sits 2.2-fold (0.34 log units) above what was measured; low and high end bracket the measured number.
By their numbers in this assay, from the lowest: compounds 1 and 3 (each within the scatter of the next); then compound 2.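

In this assay, 2-fluorophenyl and 4-fluorophenyl on the saturated chain carbon bound to an oxygen on an aromatic ring read alike (a 1.0-fold higher number from compound 1 to compound 3 (0.01 log units; within the scatter)). The step with fluoro in place of methyl on an aromatic carbon (a 7.4-fold lower number from compound 2 to compound 3 (0.87 log units; beyond the scatter)) shows that the gap separating compound 2 from compound 1 also appears between compound 2 and compound 3, so it follows the exchange of methyl and fluoro, not the place of the fluorine. From the compounds shown here alone, whether a chlorine, a methoxy group or an unsubstituted phenyl would read with compound 3 or with compound 2 stays open. No evidence at hand bears on this result.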